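The compounds below may be only part of what the source reports. "The series", "measured", "known", "first", "only" and "open" are said of these compounds alone.

Measured so far in a functional assay on HCT-116 cells (Homo sapiens) for antiproliferative activity, read by MTT assay, with a stated time of 72 h; on this read-out lower numbers stand for stronger inhibition and higher numbers for weaker inhibition:
Compound 1 `COc1ccc(/C=C2\S/C(=N\c3ccc(Cl)cc3)N(C)C2=O)cc1` gives 10400 nM.
Compound 2 `COc1ccc(/C=C2\S/C(=N\c3ccc(OC)cc3)N(C)C2=O)cc1` gives only a limit of the assay, > 100000 nM.

For the measured compounds named here, compound 2 thus stands at the limit of > 100000 nM in this assay, at which 1 of the 2 values shown sits, so no number is known for it, and compound 1 is the only compound with a measured number. Going by the values given here, the single measured step, an at least 9.6-fold higher number from compound 1 to compound 2 (0.98 log units; beyond the scatter), runs from a number to a limit and is itself open-ended.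

Compound 3 `COc1ccc(/C=C2\S/C(=N\c3c(C)cccc3C)N(C)C2=O)cc1` differs from compound 2 by 2,6-dimethylphenyl in place of 4-methoxyphenyl on a double-bonded nitrogen. Among the compounds with values here, no measured step covers this change directly; the step from compound 1 to compound 2 only shows that introducing methoxy in place of chloro pushed the number to the limit, and in compound 3 the methoxy-bearing ring leaves again. The expectation is therefore a return toward, but not necessarily to, the region of compound 1, with wide uncertainty and a real chance of another limit. The expected step is an at least 3.3-fold lower number from compound 2 to compound 3 (0.52 log units; beyond the scatter). For compound 3 the estimate in this assay is 30000 nM, within a range of 8000 nM to 150000 nM.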

Compound 3, half-maximal inhibitory concentration: > 100000 nM
Compound 3 ended at the assay's limit (the forecaster's own chance of this, stated with the estimate: 40%); middle value at least 3.3-fold (0.52 log units) away from the limit.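

In this assay compound 3 gives > 100000 nM, which is a limit of the assay. With 2,6-dimethylphenyl in place of 4-chlorophenyl on the double-bonded nitrogen, the result is an at least 9.6-fold higher number from compound 1 to compound 3 (0.98 log units; beyond the scatter), so the measurable number of compound 1 is lost here with a group that carries no methoxy, and the earlier loss is not tied to methoxy alone. The step between compound 2 and compound 3 cannot be read, and the series now stands as follows: the limit of > 100000 nM in this assay, at which 2 of the 3 values shown sit.

Among the three groups shown on this nitrogen, only the 4-chlorophenyl of compound 1 gives a number, so the ranking of the other two remains unknown. Also open, on these data alone, is whether a measurable number survives with fluoro or trifluoromethyl in place of chloro, or with an amine on that ring.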